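From a Fluorinated Aryl Amine to a Benzyl Amine

The compounds below may be only part of what the source reports. "The series", "measured", "known", "first", "only" and "open" are said of these compounds alone.

Three compounds share one core and differ only in the group on an amine nitrogen. In a functional assay on A549 cells (Homo sapiens) for cytotoxicity, read by MTT assay, with a stated time of 48 h (a higher number here means a weaker inhibitor, a lower number a stronger inhibitor), compound 1 `COc1ccc(N/C(CCNC2=CC(=O)c3ccccc3C2=O)=N\S(=O)(=O)c2ccc(C)cc2)cc1` gives 25500 nM, compound 2 `Cc1ccc(S(=O)(=O)/N=C(/CCNC2=CC(=O)c3ccccc3C2=O)Nc2ccc(F)c(F)c2)cc1` gives 16700 nM, and compound 3 `Cc1ccc(S(=O)(=O)/N=C(/CCNC2=CC(=O)c3ccccc3C2=O)Nc2cc(F)c(F)c(F)c2)cc1` gives 10200 nM, the lowest of the three numbers, though a 1.6-fold lower number from compound 2 to compound 3 (0.21 log units; within the scatter) and only a 2.5-fold lower number from compound 1 to compound 3 (0.40 log units; beyond the scatter). Compound 4 `Cc1ccc(S(=O)(=O)/N=C(/CCNC2=CC(=O)c3ccccc3C2=O)NCc2ccccc2)cc1` carries benzyl in place of 3,4,5-trifluorophenyl on an amine nitrogen. Among the compounds with values here, no measured step exchanges an aromatic ring for a benzyl group; the measured steps only swap substituents on that ring. The fluorines that accompanied the modest drop from compound 1 leave here, so the number for compound 4 is expected to move upward again, a 2.2-fold higher number from compound 3 to compound 4 (0.33 log units; beyond the scatter). Compound 4 is therefore estimated at 22000 nM, with a range from 7000 nM to 65000 nM.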

Compound 4, half-maximal inhibitory concentration: 7410 nM
Compound 4: middle estimate off by 3.0-fold (0.47 log units), on the high side; low and high end bracket the measured number.
By their numbers in this assay, from the lowest: compounds 4, 3, 2 and 1 (each within the scatter of the next, the first and the last beyond it).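

In this assay benzyl, which carries no fluorine, stands level on this amine nitrogen with 3,4,5-trifluorophenyl, showing a 1.4-fold lower number from compound 3 to compound 4 (0.14 log units; within the scatter) and so no real difference. The other two groups do separate from benzyl, with a 2.3-fold lower number from compound 2 to compound 4 (0.35 log units; beyond the scatter) and a 3.4-fold lower number from compound 1 to compound 4 (0.54 log units; beyond the scatter) as modest steps, so fluorine is not needed here to reach the lowest numbers in this series. No measurement shown explains this result.

On these data alone, whether fluorine on the benzyl ring would lower the number further remains open. So does the effect of a longer chain, such as phenethyl, or a cyclohexyl group without an aromatic ring.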